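The source may report more compounds than this note shows. Statements on the series, on what has been measured and on what is new or still open speak of the compounds shown alone.

Three compounds have been measured in an assay on HEK293 cells for antagonist activity at transient receptor potential cation channel subfamily V member 3 (Homo sapiens), read by FLIPR and calcium flux; a higher number here means a weaker inhibitor, a lower number a stronger inhibitor:

Compound 1, `O[C@H](c1ccccn1)[C@]1(c2cccc(OC(F)(F)F)c2)C[C@H](O)C1`: 40 nM
Compound 2, `O[C@H](c1ccccn1)[C@]1(c2cccc(C(F)(F)F)c2)C[C@H](O)C1`: 90 nM
Compound 3, `C[C@]1(O)C[C@@](c2ccc(C(F)(F)F)cc2)([C@H](O)c2ccccn2)C1`: 840 nM

Compound 1 and compound 2 share a core and differ in one place, (trifluoromethoxy in place of trifluoromethyl on an aromatic carbon). That change gave a 2.3-fold lower number from compound 2 to compound 1 (0.35 log units; beyond the scatter). Compound 3 stands apart from both; how its core differs from that of compound 2 is not broken down here, and its value in this assay is the highest of the three.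

Compound 4, `C[C@]1(O)C[C@@](c2ccc(OC(F)(F)F)cc2)([C@H](O)c2ccccn2)C1`, has not yet been measured. It differs from compound 3 by trifluoromethoxy in place of trifluoromethyl on an aromatic carbon. This is the same kind of change as that from compound 2 to compound 1, though the group sits para to a large group rather than meta to it. Because the earlier change gave a 2.3-fold lower number from compound 2 to compound 1 (0.35 log units; beyond the scatter), a step of similar size, a 2.1-fold lower number from compound 3 to compound 4 (0.32 log units; beyond the scatter), is expected here. Compound 4 is therefore estimated at 400 nM in this assay, between 150 nM and 1100 nM.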

Compound 4, antagonist equilibrium constant: 330 nM
Compound 4: the middle estimate sits 1.2-fold (0.08 log units) above what was measured, within the range that was stated.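

In this assay, putting trifluoromethoxy in place of trifluoromethyl gave a 2.5-fold lower number from compound 3 to compound 4 (0.41 log units; beyond the scatter). For the compounds shown here, the change therefore carried over from one core to the other with a step of matching size: the same change on two cores in this assay, a 2.3-fold lower number (0.35 log units; beyond the scatter) from compound 2 to compound 1 and a 2.5-fold lower number (0.41 log units; beyond the scatter) from compound 3 to compound 4, 1.1-fold (0.05 log units) apart, within the scatter of two such steps Two pairs show only that the step held on these two cores; they do not show that it would hold on a further core, and they do not explain why the number falls.

The compounds shown carry only trifluoromethyl or trifluoromethoxy on the aromatic ring, so how a nitrile, a chlorine or a methoxy group there would compare remains open. From the compounds shown here alone, whether an amine could stand in for a hydroxyl group on these cores is also open.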